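Methoxy addition on the fused-ring core toward compound 3

The compounds below may be only part of what the source reports. "The series", "measured", "known", "first", "only" and "open" are said of these compounds alone.

Measured so far:
- compound 1 `COc1ccccc1OCCNC[C@H](O)COc1c(OC)ccc2[nH]ccc12` — 11.3 nM
- compound 2 `COc1ccccc1OCCNCC(O)COc1cccc2[nH]ccc12` — 89.8 nM

Compound 2 stands highest of the two numbers in an assay on membranes from Cerebral cortex (strain Wistar) for displacement of a labelled ligand from Adrenergic receptor alpha-1 (Rattus norvegicus), read by scintillation counting; on this read-out lower numbers stand for stronger inhibition and higher numbers for weaker inhibition; compound 1 lies well beyond the scatter below it. Compound 3 `COc1ccccc1OCCNCC(O)COc1c(OC)ccc2[nH]ccc12` has not yet been measured. It differs from compound 2 by methoxy in place of hydrogen on an aromatic carbon. For the measured compounds named here, no measured step between compounds differing in a single place exists in this set, so the size of the move cannot be read directly from a prior pair. Compound 1 already carries this methoxy group on the same fused-ring system, differing from compound 3 only in how its stereocentre is specified, and compound 1 gives 11.3 nM, whereas compound 2 gives 89.8 nM. A step of comparable direction, toward a lower number, is expected for compound 3, though possibly smaller than that gap, as a 4.5-fold lower number from compound 2 to compound 3 (0.65 log units; beyond the scatter). Compound 3 is therefore estimated at 20 nM, with a range of 8 nM to 50 nM.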

Compound 3, inhibition constant: 21.1 nM
Beside the measured number, compound 3's estimate is 1.1-fold (0.02 log units) below it, within the range that was stated.
By their numbers in this assay, from the lowest: compounds 1 and 3 (each within the scatter of the next); then compound 2.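

In this assay, for the compounds shown here, methoxy in place of hydrogen on an aromatic carbon, ortho to a large group, gives the first single-place reading at this position: a 4.3-fold lower number from compound 2 to compound 3 (0.63 log units; beyond the scatter). The stereo pair gives a 1.9-fold higher number from compound 1 to compound 3 (0.27 log units; within the scatter), so drawing the saturated chain carbon as S shows no difference beyond the scatter. That pair does not separate the two configurations from each other, because of one feature of the comparison: the fact that one of compounds 1 and 3 is drawn with a defined configuration and the other without, at the place where they differ

Open, on these data alone, is whether ethoxy, a hydroxyl or chlorine in the same place would shift the number as methoxy does. Also open, as far as these compounds go, is where a compound drawn R at the saturated chain carbon would stand.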